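This account rests on a few compounds, and the source may have more. Where it says the series, first, only, none or still open, it means among the compounds named here.

Measured compounds:
- Compound 1 `CCNC(=O)c1noc(-c2cc(C(C)C)c(O)cc2O)c1-c1cc(CNC(C)=O)no1`, which in a functional assay on HCT-116 cells (Homo sapiens) for inhibition (a lower number here means a stronger inhibitor, a higher number a weaker inhibitor), gives 167 nM.
- Compound 2 `CCNC(=O)c1noc(-c2cc(C(C)C)c(O)cc2O)c1-c1cc(C(=O)OCC)no1`, for which this assay reports "not determined" (no result reported).

Where compound 2 stands cannot be said in numbers: in this assay it has no value, so the only anchor in the series is compound 1. The shared core is the same in both, and compound 1 differs from compound 2 only in the group carried on the second five-membered ring, so the value of compound 1 is the nearest available reference for this branch.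

Compound 3 `CCNC(=O)c1noc(-c2cc(C(C)C)c(O)cc2O)c1-c1cn[nH]c1` is the next member. Its change relative to compound 2 is 1H-pyrazol-4-yl in place of 3-(ethoxycarbonyl)-1,2-oxazol-5-yl on an aromatic carbon. For the measured compounds named here, no measured pair covers this kind of exchange, so the size of the step in this assay is open; on the reference of compound 1 a step of roughly the usual scatter in either direction is expected, with a mild lean toward weaker inhibition. Compound 3 is expected to give about 300 nM in this assay, in the range 80 nM to 1500 nM.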

Compound 3, half-maximal inhibitory concentration: 43 nM
Compound 3: middle estimate off by 7.0-fold (0.84 log units), on the high side, and the stated range ends above it.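

In this assay, for the compounds shown here, replacing 3-(acetamidomethyl)-1,2-oxazol-5-yl with 1H-pyrazol-4-yl on this aromatic carbon gives a 3.9-fold lower number from compound 1 to compound 3 (0.59 log units; beyond the scatter), the first readable step at this position. Activity at this level therefore does not require the acetamidomethyl chain or the 1,2-oxazole ring: the 1H-pyrazol-4-yl group carries neither and still gives the stronger inhibition of the pair, and it is the only entering group here with a ring hydrogen-bond donor counted in its description. The step involving compound 2 cannot be read, as compound 2 has no value in this assay, and no measurement available explains the gain seen with compound 3.

The step from compound 1 to compound 3 changes the ring and its chain together, so their separate contributions remain unresolved, and an unsubstituted 1,2-oxazol-5-yl group would be needed to divide them. Also open, from the compounds shown here alone, is whether the 1H-pyrazol-4-yl ring tolerates substitution, for example a methyl group on the ring nitrogen, an amine, a carboxylic acid or a longer chain, and how any of these would compare with compound 3 in this assay.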